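Swapping the ring group on compound 2

A few compounds are considered here, and "the series" means these few. Any claim that something is new, unique, unknown or untested is made for them only; others in the source may bear on it.

Compound 1 `CC(C)C(Cc1nnc[nH]1)c1ccc(-c2ccc3cccc(F)c3c2)[nH]c1=O` gives < 0.0667 h as a limit, not a number
Compound 2 `CC(C)C(c1ccc(-c2ccc3cccc(F)c3c2)[nH]c1=O)N1CCCCC1=O` gives 0.0967 h as a number

Going by the values given here, in an ADME assay on microsomes from liver (Mus musculus) for metabolic stability (a higher number here means that the compound lasts longer, a lower number that the compound disappears faster), compound 2 gives 0.0967 h as the only true number so far. Compound 3 `CC(C)C(c1ccc(-c2ccc3cccc(F)c3c2)[nH]c1=O)N1CCN/C1=N\C#N` is not yet measured and carries a group of 8 heavy atoms (4 carbon, 4 nitrogen; one five-membered non-aromatic ring with 2 hetero atoms) in place of a group of 7 heavy atoms (5 carbon, 1 nitrogen, 1 oxygen; one six-membered non-aromatic ring with 1 hetero atom), on a saturated chain carbon bound to an aromatic carbon and a saturated chain carbon as its change. Among the compounds with values here, the one measured step that bears on this is an at least 1.4-fold higher number from compound 1 to compound 2 (0.16 log units; that floor lies within the scatter) at that same place, with other groups. So no step beyond the scatter is expected in this assay in either direction. The expected result is a 1.2-fold higher number from compound 2 to compound 3 (0.09 log units; within the scatter) in size. Compound 3 is estimated at 0.12 h with an expected range from 0.06 h to 0.25 h in this assay.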

Compound 3, half-life: 0.207 h
Compound 3: the middle estimate sits 1.7-fold (0.24 log units) below what was measured, within the range that was stated.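

In this assay, going by these compounds alone, putting the group with the five-membered non-aromatic ring in place of 2-oxopiperidin-1-yl gives a 2.1-fold higher number from compound 2 to compound 3 (0.33 log units; beyond the scatter), the first change at this position that clearly exceeds the scatter. In place of (4H-1,2,4-triazol-3-yl)methyl, the same group gives an at least 3.1-fold higher number from compound 1 to compound 3 (0.49 log units; beyond the scatter). That step is only a floor, since compound 1 gives a limit and not a number: the limit of < 0.0667 h in this assay, at which 1 of the 3 values shown sits.

Still open, from the compounds shown here alone, is whether the higher number belongs to the nitrile or to the ring that carries it. Also open, going by these compounds, is how an amine or a carboxylic acid would behave on this saturated chain carbon.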